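Thiazol-2-yl urea in place of a fluorophenyl urea

This account rests on a few compounds, and the source may have more. Where it says the series, first, only, none or still open, it means among the compounds named here.

Of the compounds shown here, two sharing one core have been measured so far. Compound 1 `Nc1n[nH]c2cccc(-c3cccc(NC(=O)Nc4ccc(Cl)c(C(F)(F)F)c4)c3)c12` gives 1150 nM in a functional assay on SMMC-7721 cells (Homo sapiens) for inhibition, read by MTT assay, with a stated time of 48 h (on this read-out lower numbers stand for stronger inhibition and higher numbers for weaker inhibition), and compound 2 `Nc1n[nH]c2cccc(-c3cccc(NC(=O)Nc4cccc(F)c4)c3)c12` gives 1240 nM in the same assay. Compound 2 carries the highest of the two numbers, but the gap to compound 1 lies within the scatter, so the two cannot be told apart on these data.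

Compound 3 `Nc1n[nH]c2cccc(-c3cccc(NC(=O)Nc4nccs4)c3)c12` has not yet been measured. It differs from compound 2 in one place: 1,3-thiazol-2-yl in place of 3-fluorophenyl on an amide-type nitrogen. Among the measured compounds shown here, no step between measured compounds bears on this change, so no measured precedent exists for it. From compound 2 to compound 3 a moderate rise in the number, meaning weaker inhibition, is expected, but the range is wide. For compound 3 in this assay the estimated step is a 1.6-fold higher number from compound 2 to compound 3 (0.21 log units; within the scatter), giving an expected value of 2000 nM, with a range from 700 nM to 6000 nM.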

Compound 3, half-maximal inhibitory concentration: 550 nM
For compound 3 the middle estimate is 3.6-fold (0.56 log units) above the measured one, outside the stated range (below it).
By their numbers in this assay, from the lowest: compound 3; then compounds 1 and 2 (each within the scatter of the next).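

Within this assay, putting 1,3-thiazol-2-yl in place of 3-fluorophenyl on an amide-type nitrogen gives a 2.3-fold lower number from compound 2 to compound 3 (0.35 log units; beyond the scatter), a modest step but one beyond the scatter. This shows that the number responds to the group at this position, and that a five-membered aromatic ring with two hetero atoms is accepted here in place of a six-membered aromatic ring of carbon only, with stronger inhibition rather than a loss. Nothing available accounts for this step.

The compounds shown leave open whether the gain belongs to the ring nitrogen, the sulfur or the smaller ring, which a 1,3-oxazol-2-yl or pyridin-2-yl group at the same nitrogen could help to separate. They also leave open whether a methyl group on the 1,3-thiazol-2-yl ring would keep the step.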